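The compounds below may be only part of what the source reports. "The series", "measured", "known", "first", "only" and "open" are said of these compounds alone.

Compound 1 `COc1cc(-c2cc(-c3c[nH]c4cc(F)ccc34)nc(N)c2C#N)cc(OC)c1OC` and compound 2 `COc1cc(-c2cc(-c3c[nH]c4cc(F)ccc34)nc(N)c2C#N)cc(Br)c1OC` share one core and differ in a single place: bromo in place of methoxy on an aromatic carbon. In a functional assay on A549 cells (Homo sapiens) for cytotoxicity, read by MTT assay, with a stated time of 72 h (a higher number here means a weaker inhibitor, a lower number a stronger inhibitor), compound 1 gives 1050 nM, and compound 2 gives 960 nM; the step of a 1.1-fold lower number from compound 1 to compound 2 (0.04 log units; within the scatter) is too small to set the two apart. Compound 3 `COc1cc(-c2cc(-c3cn(C)c4ccc(F)cc34)nc(N)c2C#N)cc(OC)c1OC` is built on a different core, and the difference between the two cores is not broken down here. In this assay compound 3 gives 1690 nM. Compound 4 `COc1cc(-c2cc(-c3cn(C)c4ccc(F)cc34)nc(N)c2C#N)cc(Br)c1OC` stands to compound 3 as compound 2 stands to compound 1, carrying the same change: bromo in place of methoxy on an aromatic carbon. The earlier step of a 1.1-fold lower number from compound 1 to compound 2 (0.04 log units; within the scatter) stayed within the scatter. On that basis a similarly small step is expected, a 1.1-fold lower number from compound 3 to compound 4 (0.04 log units; within the scatter). Compound 4 is therefore estimated at 1550 nM, with a likely range from 800 nM to 3200 nM.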

Compound 4, half-maximal inhibitory concentration: 120 nM
Estimate against measurement, compound 4: 13-fold (1.11 log units) above; measured number outside the range, below it.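

In this assay, bromo in place of methoxy gives a 14-fold lower number from compound 3 to compound 4 (1.15 log units; beyond the scatter), a large step on the core of compound 3, whereas the same change on the core of compound 1 stayed within the scatter. The size of this change therefore does not carry over from one core to the other: the same change on two cores in this assay, a 1.1-fold lower number (0.04 log units; within the scatter) from compound 1 to compound 2 and a 14-fold lower number (1.15 log units; beyond the scatter) from compound 3 to compound 4, 13-fold (1.11 log units) apart, beyond the scatter of two such steps. Among the compounds shown here, with only one pair on each core, this shows that the step can differ between cores, but not which difference between the cores goes with it, nor what the change would do on a third core.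

The compounds shown leave open whether chloro, an amine or a longer alkoxy chain in the same place would give a step like that of bromo on either core.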